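A few compounds are considered here, and "the series" means these few. Any claim that something is new, unique, unknown or untested is made for them only; others in the source may bear on it.

Compound 2 `COc1ccccc1/C=C(/SCc1ccc(C)cc1)C(=O)c1ccc(Cl)cc1` and compound 1 `Cc1ccc(CS/C(=C/c2sccc2C)C(=O)c2ccc(Cl)cc2)cc1` share a core in which a sulfur links the side chain; in a functional assay on DU-145 cells (Homo sapiens) for inhibition, read by trypan blue exclusion, with a stated time of 96 h (a lower number here means a stronger inhibitor of growth, a higher number a weaker inhibitor of growth), compound 2 gives 10000 nM and compound 1 gives 10000 nM. The change between them, (3-methylthiophen-2-yl in place of 2-methoxyphenyl on a double-bonded chain carbon bound to a double-bonded chain carbon), makes the step of no change at the digits printed from compound 2 to compound 1 (within the scatter). Compound 3 `COc1ccccc1/C=C(\C(=O)c1ccc(Cl)cc1)S(=O)(=O)Cc1ccc(C)cc1` carries a sulfonyl in place of that sulfur; how its core differs from the core of compound 2 is not broken down here. In this assay compound 3 gives 10000 nM, level with compound 1 and compound 2. Compound 4 `Cc1ccc(CS(=O)(=O)/C(=C/c2sccc2C)C(=O)c2ccc(Cl)cc2)cc1` arises from compound 3 by the same change, (3-methylthiophen-2-yl in place of 2-methoxyphenyl on a double-bonded chain carbon bound to a double-bonded chain carbon). Because the step of no change at the digits printed from compound 2 to compound 1 (within the scatter) on the related core stayed within the scatter, the step from compound 3 to compound 4 is expected to be about no change at the digits printed from compound 3 to compound 4 (within the scatter). Compound 4 is therefore estimated at 10000 nM, likely between 5000 nM and 20000 nM, before its measurement is known.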

Compound 4, concentration for 50% growth inhibition: 25000 nM
Beside the measured number, compound 4's estimate is 2.5-fold (0.40 log units) below it, outside the stated range (above it).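

In this assay, putting 3-methylthiophen-2-yl in place of 2-methoxyphenyl gives a 2.5-fold higher number from compound 3 to compound 4 (0.40 log units; beyond the scatter) on the sulfonyl core, while on the sulfur core it gives no change at the digits printed from compound 2 to compound 1 (within the scatter). Set side by side, the two steps cannot be told apart: the same change on two cores in this assay, no change at the digits printed (within the scatter) from compound 2 to compound 1 and a 2.5-fold higher number (0.40 log units; beyond the scatter) from compound 3 to compound 4, 2.5-fold (0.40 log units) apart, within the scatter of two such steps. For the compounds shown here, the change therefore carries over between these two cores as far as this assay can show, but this rests on only two pairs and does not show that it would carry over to any other core.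

Going by these compounds, how an amine or a carboxylic acid in that same place would behave on either core stays open. Also open, on these data alone, is whether any such group would give a lower number in this assay.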